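Cytotoxicity in THP-1 cells: from methyl to dimethylamino

The compounds below may be only part of what the source reports. "The series", "measured", "known", "first", "only" and "open" are said of these compounds alone.

Measured compounds in an ADME assay on THP-1 cells (Homo sapiens) for cytotoxicity, read by MTT assay, with a stated time of 72 h; on this read-out lower numbers stand for an effect already at smaller amounts and higher numbers for an effect only at larger amounts of compound:
Compound 1 `O=c1nc(-c2ccccc2)c2cc(-c3cccnc3)ccc2[nH]1` gives > 50000 nM, a limit of the assay.
Compound 2 `Cc1ccc(-c2ccc3[nH]c(=O)nc(-c4ccccc4)c3c2)cn1` gives > 50000 nM, a limit of the assay.
Compound 3 `Cc1ccncc1-c1ccc2[nH]c(=O)nc(-c3ccccc3)c2c1` gives > 50000 nM, a limit of the assay.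

Compound 2 stands on a limit in this assay, as do the two other values shown, all sitting at the limit of > 50000 nM in this assay, at which 3 of the 3 values shown sit. The step to compound 4 `CN(C)c1ccc(-c2ccc3[nH]c(=O)nc(-c4ccccc4)c3c2)cn1` is dimethylamino in place of methyl on an aromatic carbon. The measured steps that bear on it are a step that the two limits leave unreadable from compound 1 to compound 2, a step that the two limits leave unreadable from compound 1 to compound 3 and a step that the two limits leave unreadable from compound 2 to compound 3; none of them can be read in size, because every value sits at the limit of > 50000 nM in this assay, at which 3 of the 3 values shown sit. Nothing in these data shows a change in cytotoxicity from adding a methyl on the ring or moving it, so no step beyond the scatter is expected from the dimethylamino group either. Compound 4 is therefore expected to give 50000 nM in this assay, between 20000 nM and 200000 nM, most likely again reported as a limit. The estimated step from compound 2 to compound 4 is a number no higher from compound 2 to compound 4 (the limit leaves the size open).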

Compound 4, half-maximal effective concentration: > 50000 nM
Compound 4: no number, only a limit; the forecaster's own chance of this, stated with the estimate: 85%; the middle value lies on the limit itself.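

In this assay compound 4 gives > 50000 nM as a limit of the assay. The steps from compound 1 and compound 2 to compound 4 therefore cannot be read in size: the limit of > 50000 nM in this assay, at which 4 of the 4 values shown sit. The compounds shown leave open how the methyl and dimethylamino groups would compare where cytotoxicity can be given as a number.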